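Expecting the second hydroxyamino analogue

The source may report more compounds than this note shows. Statements on the series, on what has been measured and on what is new or still open speak of the compounds shown alone.

Compound 1 `Nc1ccc(CNc2cc(Br)cc3[nH]ncc23)cc1` carries an amino group on its aromatic ring, and in an assay for inhibition of Tryptophan 2,3-dioxygenase (Homo sapiens), with a stated time of 1 h, tested at 10 uM (on this read-out lower numbers stand for less inhibition and higher numbers for more inhibition at the one concentration tested (going by the name of the read-out)), compound 1 gives 24%. Compound 3 `ONc1ccc(CNc2cc(Br)cc3[nH]ncc23)cc1` is its hydroxyamino counterpart, reached by the change (hydroxy in place of hydrogen on a nitrogen on an aromatic ring), and in this assay compound 3 gives 6%. The step of a number 18 percentage points lower from compound 1 to compound 3 (beyond the scatter) therefore runs downward. Compound 2 `Nc1cccc(CNc2cc(Br)cc3[nH]ncc23)c1` has the same atoms as compound 1 joined differently; the difference between the two cores is not broken down here. In this assay compound 2 gives "not active" (no number reported), and no number was reported for it. Compound 4 `ONc1cccc(CNc2cc(Br)cc3[nH]ncc23)c1` stands to compound 2 as compound 3 stands to compound 1: the change hydroxy in place of hydrogen on a nitrogen on an aromatic ring is the same change, at a place described in the same words. Within the data shown here, the one measured instance of this change, a number 18 percentage points lower from compound 1 to compound 3 (beyond the scatter), lowered the read-out modestly, and compound 2 itself returned no number. On that basis compound 4 is expected to sit low in this assay, with an estimated reading of 3% and a likely range from -6% to 12%. On these data alone, whether a number is returned for compound 4 at all remains open.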

Compound 4, a percentage reported as inhibition, at one concentration (the size of the read-out at that concentration, not a potency): "not active" (no number reported)
For compound 4 the study gives words and no number; the estimate stays without a comparison.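

Compound 2 gives "not active" (no number reported) and compound 4 gives "not active" (no number reported) so neither side of this pair carries a number, and no step can be read between them. The compounds shown leave open whether the amino to hydroxyamino change seen in the step of a number 18 percentage points lower from compound 1 to compound 3 (beyond the scatter) has any measurable size in compound 2 and compound 4. Nothing further is available that bears on this result.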